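This account rests on a few compounds, and the source may have more. Where it says the series, first, only, none or still open, it means among the compounds named here.

Measured so far in an in vitro ADME assay on microsomes (Mus musculus) for metabolic stability (on this read-out lower numbers stand for a shorter-lived compound and higher numbers for a longer-lived compound), for two compounds on a shared core
Compound 1 `O=C(Nc1ccccc1)Nc1ccc(-c2nc(C3=CCOCC3)c3sccc3n2)cc1` gives 21 h as a measured number
Compound 2 `O=C(Nc1ccc(-c2nc(C3=CCOCC3)c3sccc3n2)cc1)Nc1cccnc1` gives > 30 h as a limit of the assay

Going by these compounds, compound 2 stands at the limit of > 30 h in this assay, at which 1 of the 2 values shown sits, and that is a limit of the assay, not a number, so how far its half-life reaches is unknown. The change to compound 3 `O=C(Nc1ccncc1)Nc1ccc(-c2nc(C3=CCOCC3)c3sccc3n2)cc1` is pyridin-4-yl in place of pyridin-3-yl on an amide-type nitrogen, and pyridin-4-yl in place of pyridin-3-yl on an amide-type nitrogen is the full count of it. Within the data shown here, the only measured step that bears on this change is an at least 1.4-fold higher number from compound 1 to compound 2 (0.15 log units; that floor lies within the scatter) with pyridin-3-yl in place of phenyl on an amide-type nitrogen. Among the measured compounds shown here, no measured step compares the two pyridinyl groups directly. For the measured compounds named here, with an at least 1.4-fold higher number from compound 1 to compound 2 (0.15 log units; that floor lies within the scatter) as the only guide, no step beyond the scatter is expected in this assay in either direction. The expected step is a number no higher from compound 2 to compound 3 (the limit leaves the size open) as an estimate resting on that single comparison. Compound 3 is expected at 30 h with an estimated range from 15 h to 60 h.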

Compound 3, half-life: > 30 h
Compound 3 was reported as a limit; the forecaster's own chance of this, stated with the estimate: 55%; the middle value sits exactly at the limit.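

On this amide-type nitrogen, pyridin-4-yl now has its own comparison with phenyl in this assay: there is an at least 1.4-fold higher number from compound 1 to compound 3 (0.15 log units; that floor lies within the scatter). Among these compounds, this means that pyridin-3-yl is no longer the only pyridinyl group to set against phenyl at this place, and compound 3 joins compound 2 at a limit of the assay rather than giving a number. The step between the two pyridinyl groups cannot be read, because both compounds sit at that limit, so the result gives no order for pyridin-3-yl and pyridin-4-yl: the limit of > 30 h in this assay, at which 2 of the 3 values shown sit.

Going by these compounds, how far the half-life of compound 2 or compound 3 reaches remains open, and so does whether the two pyridinyl groups differ at all in this assay. On these data alone, it is also open how pyridin-2-yl, or a phenyl carrying an amine or a carboxylic acid, would read on this same nitrogen with the shared core unchanged.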